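Aryl for alkyl on the ring nitrogen of compound 3

The compounds below may be only part of what the source reports. "The series", "measured", "known", "first", "only" and "open" are said of these compounds alone.

Compound 3 `CCCCn1c(S)nnc1COc1ccc(-c2ccccc2)cc1` is the starting point of this step. Within the data shown here, in a functional assay on the whole organism (strain Wistar) for inhibition, with Rattus norvegicus as the target, read by paw edema, with a stated time of 3 h, at a dose of 10 mg/kg by the oral route (a lower number here means less inhibition, a higher number more inhibition at the dose given (going by the name of the read-out)), compound 3 gives 75%, the second highest of the three numbers so far. Compound 2 `CC(C)Cc1ccc(C(C)c2nnc(COc3ccc(-c4ccccc4)cc3)o2)cc1` gives 77.3%, which sits within the scatter of compound 3. Compound 1 `c1ccc(-c2ccc(OCc3nnc(-c4ccccc4)o3)cc2)cc1` gives 18.2%, a number beyond the scatter and far lower than compound 3. Compound 4 `Cc1ccccc1-n1c(S)nnc1COc1ccc(-c2ccccc2)cc1` is not yet measured; it differs from compound 3 by 2-methylphenyl in place of butyl on an aromatic nitrogen. Among the measured compounds shown here, no measured pair shows this change, so its size is open. In this assay no step beyond the scatter is expected for compound 4, in either direction. The estimate for compound 4 is 70%, with a range from 50% to 85%. The step expected from this estimate is a number 5 percentage points lower from compound 3 to compound 4 (within the scatter).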

Compound 4, a percentage reported as inhibition, in the whole organism at one dose (the size of the read-out at that dose, not a potency): 56.8%
Compound 4: middle estimate off by 13.2 percentage points, on the high side, and the stated range covers the measured number.
By their numbers in this assay, from the lowest: compound 1; then compound 4; then compounds 3 and 2 (each within the scatter of the next).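

Replacing butyl with 2-methylphenyl on the aromatic nitrogen gives a number 18.2 percentage points lower from compound 3 to compound 4 (beyond the scatter) in this assay and is a modest change beyond the scatter. Among these compounds, this is the first sign that the group at this position affects paw edema inhibition at the dose given, and the aryl group does not match butyl here. No measurement at hand accounts for the step.

Plain phenyl would separate the effect of the ring from that of its methyl group. Ethyl or hexyl would show how the read-out follows chain length at this position.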